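This account rests on a few compounds, and the source may have more. Where it says the series, first, only, none or still open, it means among the compounds named here.

Working notes on the series, all read in a physicochemical assay for lipophilicity, read by HPLC, at pH 7.5 (on this read-out higher numbers stand for higher lipophilicity and lower numbers for lower lipophilicity), as the single scale. Compound 1 (`CCOc1ccccc1-c1ccc(-c2nc3cnccc3cc2C#N)cc1`) gives 3.8 on this scale, compound 2 (`CCOc1ccccc1-c1ccc(-c2nc3cnccc3c(C[C@H](C)C(N)=O)c2C#N)cc1`) gives 3 and compound 3 (`CCCCC(Nc1c(C#N)c(-c2ccc(-c3ccccc3OCC)cc2)nc2cnccc12)C(N)=O`) gives 3.6 in the same measurement. Compound 3 stands level with compound 1 within the scatter (a number 0.20 log units lower from compound 1 to compound 3 (within the scatter)) and clearly apart from compound 2 (a number 0.60 log units higher from compound 2 to compound 3 (beyond the scatter)).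

The next entry is compound 4 (`CCOc1ccccc1-c1ccc(-c2nc3cnccc3c(NC(COC)C(N)=O)c2C#N)cc1`). Its change is methoxy in place of propyl on a saturated chain carbon, two bonds along the chain from a carbonyl carbon and a nitrogen on an aromatic ring in the side group of compound 3: methoxy in place of propyl on a saturated chain carbon, two bonds along the chain from a carbonyl carbon and a nitrogen on an aromatic ring. The same difference reads butyl to methoxymethyl.

Going by the values given here, no measured step makes this exact swap, so the guide is indirect. The closest comparison is between the side groups of compound 2 and compound 3, a modest step (a number 0.60 log units higher from compound 2 to compound 3 (beyond the scatter)). The step that brought in the group of compound 2 (a number 0.80 log units lower from compound 1 to compound 2 (beyond the scatter)) is of similar size. A modest downward move is therefore expected, beyond the scatter but not large. The expected step is a number 0.70 log units lower from compound 3 to compound 4 (beyond the scatter) (an estimate). For compound 4 the expected value is 2.9 (estimated range 2.5 to 3.3).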

Compound 4, distribution coefficient: 2.8
Compound 4: the middle estimate sits 0.10 log units above what was measured; the measured number falls inside the stated range.
By their numbers in this assay, from the lowest: compounds 4 and 2 (each within the scatter of the next); then compounds 3 and 1 (each within the scatter of the next).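

In this assay, going by these compounds alone, this is the first read of a change confined to the saturated chain carbon, with the carbamoyl group and the nitrogen on the aromatic ring held fixed: methoxy in place of propyl gives a number 0.80 log units lower from compound 3 to compound 4 (beyond the scatter) and so moves the number beyond the scatter. The whole (1-carbamoyl-2-methoxyethyl)amino group in place of hydrogen gives a number 1.00 log units lower from compound 1 to compound 4 (beyond the scatter) on the core of compound 1, while the same group in place of 2-carbamoylpropyl gives a number 0.20 log units lower from compound 2 to compound 4 (within the scatter) and leaves those two different side groups level on this scale. Nothing at hand accounts for these steps.

Going by these compounds, whether the step follows the oxygen or the shorter chain stays open, since butyl to methoxymethyl changes both at once, and an ethoxymethyl or a pentyl group at this chain carbon would help to separate the two. On these data alone, how an amine or a carboxylic acid at the end of this chain would read on the same scale also stays open.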